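The source may report more compounds than this note shows. Statements on the series, on what has been measured and on what is new or still open speak of the compounds shown alone.

Measured in a functional assay on A549 cells (Homo sapiens) for inhibition, read by MTT assay, with a stated time of 48 h; on this read-out higher numbers stand for weaker inhibition and lower numbers for stronger inhibition:
- Compound 1 `O=C(Nc1ccncc1)Nc1cc(-c2cccnc2)cc(C(F)(F)F)c1`: > 300000 nM (a limit of the assay, not a number)
- Compound 2 `O=C(Nc1ccncc1)Nc1cc(-c2cccnc2)ccc1OC(F)(F)F`: 39800 nM
- Compound 3 `Cn1cnc(-c2cc(NC(=O)Nc3ccncc3)cc(C(F)(F)F)c2)c1`: 39400 nM

Compound 1 gives only a limit, > 300000 nM. Compound 2 gives 39800 nM and compound 3 gives 39400 nM, two values within the scatter of each other.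

Compound 4 `Cn1cnc(-c2ccc(OC(F)(F)F)c(NC(=O)Nc3ccncc3)c2)c1` keeps the core of compound 2 but carries 1-methyl-1H-imidazol-4-yl in place of pyridin-3-yl on an aromatic carbon, para to a trifluoromethoxy group: 1-methyl-1H-imidazol-4-yl in place of pyridin-3-yl on an aromatic carbon. The same exchange has been measured once, on the core of compound 1, giving an at least 7.6-fold lower number from compound 1 to compound 3 (0.88 log units; beyond the scatter). Going by these compounds, that single step starts from a limit, so its true size is unknown, and it was taken on a different core. A lower number is therefore expected in this assay, but only a modest step. The expected change is a 2.7-fold lower number from compound 2 to compound 4 (0.42 log units; beyond the scatter). For compound 4 the estimated value is 15000 nM, with an expected range of 4000 nM to 55000 nM.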

Compound 4, half-maximal inhibitory concentration: 79300 nM
Compound 4: the middle estimate sits 5.3-fold (0.72 log units) below what was measured; measured number above the stated range.
By their numbers in this assay, from the lowest: compounds 3, 2 and 4 (each within the scatter of the next). At a limit, above all of these: compound 1.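

In this assay the exchange of pyridin-3-yl for 1-methyl-1H-imidazol-4-yl on this core brings no gain, with a 2.0-fold higher number from compound 2 to compound 4 (0.30 log units; within the scatter) leaving the two compounds indistinguishable. The lower number seen on the core of compound 1 therefore does not carry over to this core, so the exchange has no single effect across the two cores: the same change on two cores in this assay, an at least 7.6-fold lower number (0.88 log units; beyond the scatter) from compound 1 to compound 3 and a 2.0-fold higher number (0.30 log units; within the scatter) from compound 2 to compound 4, at least 15-fold (1.18 log units) apart, beyond the scatter of two such steps

Going by these compounds, whether another group at this position, such as an amine or a carboxylic acid, would give a lower number on either core stays open. How the exchange behaves on any third core is also unknown.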